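Adding a cyano group on the way to compound 4

The source may hold more compounds than are shown below. What is called first, only, known or untested is meant among the compounds shown, and "the series" means these compounds.

Compound 1 `O=C(NCc1ccc(OCc2ccccc2)cc1)n1cccn1` in an assay on membranes from brain for binding affinity to neutral cholesterol ester hydrolase 1 (Mus musculus), read by fluorescence, with stated times of 1 h and 30 min (on this read-out lower numbers stand for stronger inhibition and higher numbers for weaker inhibition), gives only a limit, > 100000 nM.
Compound 2 `N#Cc1cnn(C(=O)NCc2ccc(OCc3ccccc3)cc2)c1` in this assay also gives only a limit, > 100000 nM.
Compound 3 `O=C(N1CCCN(Cc2ccc(OCc3ccccc3)cc2)CC1)n1cccn1` in this assay likewise gives only a limit, > 100000 nM.

Each of these three values is the upper limit of the measurement rather than a number, as stated by the limit of > 100000 nM in this assay, at which 3 of the 3 values shown sit. Compound 1 and compound 2 differ in one place: cyano in place of hydrogen on an aromatic carbon. Because both values are limits, the step that the two limits leave unreadable from compound 1 to compound 2 cannot be read in either direction, and nothing can be said about whether the cyano group helps or hurts. Compound 3 carries a different core; the difference between the two cores is not broken down here.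

Compound 4 `N#Cc1cnn(C(=O)N2CCCN(Cc3ccc(OCc4ccccc4)cc3)CC2)c1` has not yet been measured in this assay. It relates to compound 3 exactly as compound 2 relates to compound 1: cyano in place of hydrogen on an aromatic carbon, the same change at the same place. Among the measured compounds shown here, the only guide for compound 4 is that compound 3 sits at the limit > 100000 nM and that the matching step from compound 1 to compound 2 left both partners at that limit. On that basis the expected step from compound 3 to compound 4 is a step that the limit leaves unreadable from compound 3 to compound 4, which is an estimate and not a measurement. The expected value for compound 4 in this assay is therefore 200000 nM, with a likely range from 40000 nM to 1000000 nM, and most probably another limit rather than a number.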

Compound 4, half-maximal inhibitory concentration: > 100000 nM
Compound 4: a limit, no number; the forecaster's own chance of this, stated with the estimate: 85%; the middle value does not contradict the limit.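

In this assay, compound 4 gives only a limit and no number, as compound 3 does, so the change from compound 3 to compound 4 cannot be read in either direction: the limit of > 100000 nM in this assay, at which 4 of the 4 values shown sit.

The compounds shown leave open whether swapping hydrogen for cyano changes inhibition at all on either core, and which structure, if any, would give a readable number in this assay.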